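This account rests on a few compounds, and the source may have more. Where it says the series, first, only, none or still open, it means among the compounds named here.

Measured in an ADME assay on cells (Peritoneal macrophage, Mus musculus, strain BALB/c) for cytotoxicity, with a stated time of 72 h; a lower number here means that less compound is tolerated, a higher number that more compound is tolerated:

Compound 1 `Oc1ccccc1/C=N/Nc1ncccn1`: 84200 nM
Compound 2 `Oc1cccc(/C=N/Nc2ncccn2)c1O`: > 150000 nM
Compound 3 `Cc1ccc(/C=N/Nc2ncccn2)c(O)c1`: 54800 nM

Compound 2 has the entry > 150000 nM, which is a limit of the assay and not a number. That leaves two full numbers. For the measured compounds named here, compound 1 gives 84200 nM, and the only other full number belongs to compound 3, with 54800 nM. The two sit within the scatter of each other.

Compound 4 `O=[N+]([O-])c1ccc(O)c(/C=N/Nc2ncccn2)c1` has not yet been measured. Its change from compound 1 is nitro in place of hydrogen on an aromatic carbon, para to a hydroxy group (nitro in place of hydrogen on an aromatic carbon).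

Going by the values given here, two measured steps bear on this change, though neither brings in a nitro group. The first is an at least 1.7-fold higher number from compound 1 to compound 2 (0.25 log units; that floor lies within the scatter), and the second is a 1.5-fold lower number from compound 1 to compound 3 (0.19 log units; within the scatter). Neither shows a change beyond the scatter, so no large step is expected in this assay. Among the compounds with values here, the estimate leans slightly downward, following the one step that ends in a full number, a 1.5-fold lower number from compound 1 to compound 3 (0.19 log units; within the scatter). The expected result is a 1.7-fold lower number from compound 1 to compound 4 (0.23 log units; within the scatter), which would stay within the scatter. For compound 4 the expected value is 50000 nM, with an estimated range from 15000 nM to 130000 nM.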

Compound 4, half-maximal cytotoxic concentration: 23800 nM
Beside the measured number, compound 4's estimate is 2.1-fold (0.32 log units) above it; low and high end bracket the measured number.
By their numbers in this assay, from the lowest: compound 4; then compounds 3 and 1 (each within the scatter of the next). At a limit, above all of these: compound 2.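

In this assay, for the compounds shown here, nitro in place of hydrogen on an aromatic carbon, para to a hydroxy group, gives the first step in this set that lies beyond the scatter: a 3.5-fold lower number from compound 1 to compound 4 (0.55 log units; beyond the scatter). Going by these compounds alone, the methyl change had stayed within the scatter, a 1.5-fold lower number from compound 1 to compound 3 (0.19 log units; within the scatter), and the hydroxy change ends at a limit, an at least 1.7-fold higher number from compound 1 to compound 2 (0.25 log units; that floor lies within the scatter), so this nitro step is the first to show that a single change on this ring of compound 1 can clearly lower the concentration the macrophages tolerate. Nothing given here accounts for the size of this step, and one compound cannot separate the nitro group itself from the place it occupies.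

On these data alone, whether an amine, a carboxylic acid or a methoxy group at this same place would lower the number as far stays open, as does the outcome for a nitro group elsewhere on the ring. As far as these compounds go, compound 2 gives > 150000 nM, which is a limit of the assay and not a number, so the full size of the hydroxy change also stays open.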